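The source may hold more compounds than are shown below. What is called first, only, known or untested is meant among the compounds shown, and "the series" means these compounds.

Measured so far in a functional assay on HCT-116 cells (Homo sapiens) for antiproliferative activity, read by MTT assay, with a stated time of 48 h; on this read-out higher numbers stand for weaker inhibition and lower numbers for stronger inhibition:

- compound 1 `CCCCCCC[C@@H](CCO)n1cnc2c(Cl)ncnc21`: 10700 nM
- compound 2 `CCCCCCCC[C@@H](CCO)n1cnc2c(Cl)ncnc21`: 3400 nM
- compound 3 `CCCCCCCCC[C@H](CCO)n1cnc2c(Cl)ncnc21`: 450 nM

Compound 3 has the lowest number of the three, so it is the strongest inhibitor here, and its gaps to compound 1 and compound 2 both lie beyond the usual scatter. The next molecule is compound 4 `CCCCCCCCC[C@@H](CCO)n1cnc2c(Cl)ncnc21`. Its relation to compound 3 is simple: the two compounds have the same atoms and bonds and differ only in configuration as drawn: 1 of 1 stereo elements differ; a stereocentre at a saturated chain carbon is drawn R in compound 3 and S in compound 4. Within the data shown here, no measured pair differs in configuration alone, so the size of this kind of change cannot be read directly from the data.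

Among the measured compounds shown here, the only measured step that bears on it is indirect. It is a 3.1-fold lower number from compound 1 to compound 2 (0.50 log units; beyond the scatter), a modest gain from adding a methyl to the chain. Compound 4 has the chain of compound 3 but the configuration drawn in compound 1 and compound 2. Compound 3 differs from compound 2 in both chain and configuration, so its lead cannot be assigned to either change. If the chain gain repeats, compound 4 should fall below compound 2 at 3400 nM but probably stay above compound 3 at 450 nM.

The expected change is modest and upward, a 2.2-fold higher number from compound 3 to compound 4 (0.35 log units; beyond the scatter). The estimate for compound 4 is 1000 nM, with an expected range from 350 nM to 2800 nM.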

Compound 4, half-maximal inhibitory concentration: 1050 nM
The estimate for compound 4 lay 1.1-fold (0.02 log units) below the measured number, within the range that was stated.
By their numbers in this assay, from the lowest: compound 3; then compound 4; then compound 2; then compound 1.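

In this assay, among these compounds, configuration at the saturated chain carbon now has a measured effect of its own, a 2.3-fold higher number from compound 3 to compound 4 (0.37 log units; beyond the scatter), and this is the first pair in which nothing else can account for a gap in the numbers: the fact that compounds 3 and 4 differ only in the configuration as drawn. With the configuration kept as drawn in compound 1, compound 2 and compound 4, the chain can also be read without that complication: a further methyl on the chain gives a 3.2-fold lower number from compound 2 to compound 4 (0.51 log units; beyond the scatter), a second modest gain after the first methyl step, while the ethyl comparison gives a 10-fold lower number from compound 1 to compound 4 (1.01 log units; beyond the scatter), a large gain. Within this series, then, both chain length and configuration matter, and each added carbon in the series of compound 1, compound 2 and compound 4 lowers the number.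

On these data alone, it remains open whether the configuration of compound 3 would bring a similar gain on the chains of compound 1 and compound 2. Also open, as far as these compounds go, is whether a longer chain, or an amine or a carboxylic acid in place of the hydroxyl, would lower the number further.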